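Methoxymethyl for formyl on the pyrrole carbon of the core

A few compounds are considered here, and "the series" means these few. Any claim that something is new, unique, unknown or untested is made for them only; others in the source may bear on it.

Measured so far:
compound 1 `CCCCN(CC)c1nc(C)nc2c1c(C)c(CO)n2-c1c(C)cc(C)cc1C` — 6 nM
compound 2 `CCCCN(CC)c1nc(C)nc2c1c(C)c(C=O)n2-c1c(C)cc(C)cc1C` — 52 nM

Among the compounds with values here, in a functional assay on CHO cells for antagonist activity at corticotropin-releasing factor receptor 1 (Homo sapiens), read by cAMP accumulation (on this read-out lower numbers stand for stronger inhibition and higher numbers for weaker inhibition), compound 2 stands at the higher of the two numbers known; its only neighbour is compound 1, and the step of an 8.7-fold higher number from compound 1 to compound 2 (0.94 log units; beyond the scatter) is the single change measured so far. Compound 3 `CCCCN(CC)c1nc(C)nc2c1c(C)c(COC)n2-c1c(C)cc(C)cc1C` differs from compound 2 by methoxymethyl in place of formyl on an aromatic carbon. Within the data shown here, no measured step covers this exact exchange. Among the measured compounds shown here, the one step available shows that this position answers to a change of substituent, and the entering methoxymethyl shares with the hydroxymethyl of compound 1 a saturated carbon between ring and oxygen, which the formyl of compound 2 lacks. Compound 3 is therefore expected to move back toward compound 1, by about a 3.7-fold lower number from compound 2 to compound 3 (0.57 log units; beyond the scatter), though not fully, since the methyl on oxygen is new to the series. The estimate for compound 3 in this assay is 14 nM, with a plausible range from 4 nM to 45 nM.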

Compound 3, inhibition constant: 11 nM
The estimate for compound 3 lay 1.3-fold (0.10 log units) above the measured number; the measured number falls inside the stated range.
By their numbers in this assay, from the lowest: compounds 1 and 3 (each within the scatter of the next); then compound 2.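

Methoxymethyl in place of formyl on this aromatic carbon gives a 4.7-fold lower number from compound 2 to compound 3 (0.67 log units; beyond the scatter) in this assay and so shows that a second group with a saturated carbon bearing oxygen stands apart from the formyl. Methyl in place of hydrogen on that oxygen gives a 1.8-fold higher number from compound 1 to compound 3 (0.26 log units; within the scatter) and so shows that this read-out does not separate the ether from the alcohol. Nothing at hand explains why the formyl compound stands apart from the other two.

The compounds shown leave open whether the oxygen is needed at all, which an ethyl group on the same carbon would address, and how far the chain on that oxygen can grow, which ethoxymethyl or benzyloxymethyl would address. An acetyl group would show whether the result for formyl extends to other carbonyl groups at this carbon.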